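The compounds below may be only part of what the source reports. "The series", "measured", "known", "first", "only" and "open" are said of these compounds alone.

Measured so far in a functional assay on HT-29 cells (Homo sapiens); a lower number here means a stronger inhibitor of growth, a higher number a weaker inhibitor of growth:
Compound 1 `N#Cc1ccc(/C=C/S(=O)(=O)Cc2ccc(Nc3ncnc4ccccc34)cc2)cc1`: > 100000 nM, a limit of the assay and not a number
Compound 2 `O=S(=O)(/C=C/c1ccc(Cl)c(Cl)c1)Cc1ccc(Nc2ncnc3ccccc23)cc1`: 11000 nM
Compound 3 `O=S(=O)(/C=C/c1ccc(Cl)cc1)Cc1ccc(Nc2ncnc3ccccc23)cc1`: 73000 nM

Among the compounds with values here, only two of these values are true numbers, and compound 3 holds the higher one, which makes it the weaker growth inhibitor of that pair: a 6.6-fold higher number from compound 2 to compound 3 (0.82 log units; beyond the scatter).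

Compound 4 `O=S(=O)(/C=C/c1ccc(C(F)(F)F)cc1F)Cc1ccc(Nc2ncnc3ccccc23)cc1` changes the group on a double-bonded chain carbon bound to a double-bonded chain carbon, with 2-fluoro-4-(trifluoromethyl)phenyl in place of 4-chlorophenyl on a double-bonded chain carbon bound to a double-bonded chain carbon.

Earlier changes to this group bear on the question. One is an at least 9.0-fold lower number from compound 1 to compound 2 (0.95 log units; beyond the scatter), and another is an at least 1.3-fold lower number from compound 1 to compound 3 (0.13 log units; that floor lies within the scatter). Within the data shown here, these steps, together with the one from compound 2, show that such swaps can be modest in size or more. Among the measured compounds shown here, no measured compound carries fluoro or trifluoromethyl, so no direction is firmly supported, and a large step is not expected.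

The estimated change is a 1.8-fold lower number from compound 3 to compound 4 (0.26 log units; within the scatter). For compound 4 the expected value is 40000 nM, with an estimated range of 10000 nM to 100000 nM.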

Compound 4, concentration for 50% growth inhibition: 100000 nM
The estimate for compound 4 lay 2.5-fold (0.40 log units) below the measured number, and the stated range covers the measured number.
By their numbers in this assay, from the lowest: compound 2; then compounds 3 and 4 (each within the scatter of the next).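

In this assay, 2-fluoro-4-(trifluoromethyl)phenyl, with more heavy atoms than the 4-chlorophenyl it replaces, gives no readable difference at this place: a 1.4-fold higher number from compound 3 to compound 4 (0.14 log units; within the scatter). Among the true numbers, the 3,4-dichlorophenyl of compound 2 stands apart from this new group as well, as shown by a 9.1-fold higher number from compound 2 to compound 4 (0.96 log units; beyond the scatter). One further step cannot be read for its size: a number no higher from compound 1 to compound 4 (the limit leaves the size open). Compound 1 carries a limit of the assay and not a number: the limit of > 100000 nM in this assay, at which 1 of the 4 values shown sits.

As far as these compounds go, the fluoro and the trifluoromethyl enter together in compound 4, and their separate shares stay open. Also open, from the compounds shown here alone, is how a phenyl ring carrying a methoxy group or an amine would read at this place in this assay.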